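The source may report more compounds than this note shows. Statements on the series, on what has been measured and on what is new or still open speak of the compounds shown alone.

Compound 1 `CC(C)[C@@H](c1ccc(-c2ccc3cccc(F)c3c2)[nH]c1=O)[C@H]1OC(=O)NC1=O` is the more stable of the two compounds measured in an ADME assay on microsomes from liver (Rattus norvegicus) for metabolic stability (a higher number here means that the compound lasts longer, a lower number that the compound disappears faster), where compound 1 gives 1.93 h. Compound 2 `CC(C)C(c1ccc(-c2ccc3cccc(F)c3c2)[nH]c1=O)C1SC(=O)NC1=O` shows the lower number, and in this assay compound 2 gives 0.76 h, a gap that lies beyond the usual scatter. Compound 3 `CC(C)[C@H](C[C@@H]1OC(=O)NC1=O)c1ccc(-c2ccc3cccc(F)c3c2)[nH]c1=O` differs from compound 1 in one place: (2,4-dioxo-1,3-oxazolidin-5-yl)methyl in place of 2,4-dioxo-1,3-oxazolidin-5-yl on a saturated chain carbon bound to an aromatic carbon and a saturated chain carbon. Among the measured compounds shown here, no measured pair shows this change, so the expected step of a 1.3-fold lower number from compound 1 to compound 3 (0.11 log units; within the scatter) is small, if anything a slight decrease, and within the scatter. Compound 3 is therefore expected to give about 1.5 h, with a likely range from 0.7 h to 3.2 h.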

Compound 3, half-life: 0.503 h
Estimate against measurement, compound 3: 3.0-fold (0.47 log units) above; the whole stated range lies above it.
By their numbers in this assay, from the lowest: compounds 3 and 2 (each within the scatter of the next); then compound 1.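

In this assay, (2,4-dioxo-1,3-oxazolidin-5-yl)methyl in place of 2,4-dioxo-1,3-oxazolidin-5-yl gives a 3.8-fold lower number from compound 1 to compound 3 (0.58 log units; beyond the scatter), so the number at this saturated chain carbon responds to a change of a single added carbon. The step is one pair only, and no pattern can be drawn from it. Nothing available accounts for the drop.

From the compounds shown here alone, it remains open whether a longer chain carrying the same ring would lower the number in this assay further, and how a carboxylic acid or an amine would fare at this place.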